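A few compounds are considered here, and "the series" means these few. Any claim that something is new, unique, unknown or untested is made for them only; others in the source may bear on it.

Of the compounds shown here, three sharing one core have so far been measured, and the fourth waits for its number. Compound 1 `CCn1c(C(=O)N(C)CCC#N)ccc1C(CC)(CC)c1ccc(OCC(=O)C(C)(C)C)c(C)c1` is the weakest of the three in an assay on HL-60 cells for agonist activity at vitamin D3 receptor (Homo sapiens), read by microscopy, with a stated time of 96 h (on this read-out lower numbers stand for an effect already at smaller amounts and higher numbers for an effect only at larger amounts of compound), where compound 1 gives 9800 nM. Compound 2 `CCn1c(C(=O)N(C)CCC#N)ccc1C(CC)(CC)c1ccc(OCC(O)C(C)(C)C)c(C)c1` gives 1960 nM in this assay, and compound 3 `CCn1c(C(=O)N(C)CC(=O)O)ccc1C(CC)(CC)c1ccc(OCC(O)C(C)(C)C)c(C)c1` gives 740 nM. Two single changes connect them: a 5.0-fold lower number from compound 1 to compound 2 (0.70 log units; beyond the scatter), and a 2.6-fold lower number from compound 2 to compound 3 (0.42 log units; beyond the scatter).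

Compound 4 `CCn1c(C(=O)Nc2ccc(OC(F)(F)F)cc2)ccc1C(CC)(CC)c1ccc(OCC(=O)C(C)(C)C)c(C)c1` is built from compound 1 by one change: (4-(trifluoromethoxy)phenyl)amino in place of (2-cyanoethyl)(methyl)amino on a carbonyl carbon. Within the data shown here, of the two measured steps, only the one from compound 2 to compound 3 touches the same region, the group carried on the amide-type nitrogen, and there the number fell only modestly with a 2.6-fold lower number from compound 2 to compound 3 (0.42 log units; beyond the scatter). The step from compound 1 to compound 2 alters a different part of the molecule and says nothing direct about this exchange. The new group is larger than anything tried at this position, so the outcome is uncertain; a modest movement in either direction, or none beyond the scatter, would fit what has been seen. Compound 4 is therefore estimated at 5000 nM, with a range from 1000 nM to 25000 nM, an expected step of a 2.0-fold lower number from compound 1 to compound 4 (0.29 log units; within the scatter) from compound 1.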

Compound 4, half-maximal effective concentration: > 50000 nM
Compound 4: a limit, no number (the forecaster's own chance of this, stated with the estimate: 15%); middle value at least 10-fold (1.00 log units) from the limit.
By their numbers in this assay, from the lowest: compound 3; then compound 2; then compound 1. At a limit, above all of these: compound 4.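

Compound 4 shows that the group on this carbonyl carbon can also push the number up in this assay: (4-(trifluoromethoxy)phenyl)amino in place of (2-cyanoethyl)(methyl)amino gives an at least 5.1-fold higher number from compound 1 to compound 4 (0.70 log units; beyond the scatter). Among these compounds, the only earlier step in this region, a 2.6-fold lower number from compound 2 to compound 3 (0.42 log units; beyond the scatter), went the other way, so the direction of change here depends on which group is attached. For compound 4 the read-out is a limit of the assay and not a number, which means the step has a lower bound but no exact size: the limit of > 50000 nM in this assay, at which 1 of the 4 values shown sits.

The entering group differs from the leaving one in several ways at once, bringing a six-membered aromatic ring of carbon only, a trifluoromethoxy group and an amide hydrogen, and the compounds shown do not separate these features. On these data alone, a plain phenylamino group without the trifluoromethoxy, or a small methylamino group, would help to separate them, and it also remains open whether the same exchange would act alike on the core of compound 2, which carries a hydroxyl where compound 1 has a carbonyl.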